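Chain extension between the aryl ether and the acetamide

The source may hold more compounds than are shown below. What is called first, only, known or untested is meant among the compounds shown, and "the series" means these compounds.

Two compounds of this set have numbers in an assay (Ovis aries) for binding affinity to melatonin receptor type 1A (Homo sapiens); on this read-out higher numbers stand for weaker inhibition and lower numbers for stronger inhibition. Compound 1 `COc1ccc2cccc(C3CNC(=O)C3)c2c1` gives 1580 nM. Compound 2 `CC(=O)NCCCOc1cccc2c1OCCO2` gives 631 nM, the lower of the two numbers, and the gap to compound 1 is beyond the usual scatter. Among the measured compounds shown here, no pair of measured compounds differs in a single place, so no single-point step is available for this assay.

Compound 3 `CC(=O)NCCCCOc1cccc2c1OCCO2` is the next member: it carries acetamidomethyl in place of acetamido on a saturated chain carbon, three bonds along the chain from an oxygen on an aromatic ring. Read one bond further out, the same change is acetamidomethyl to 2-acetamidoethyl, that is, one more saturated carbon in the chain that joins the aromatic ether oxygen to the acetamide.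

For the measured compounds named here, there is no measured step against which this change can be weighed. The expectation rests only on the change itself: the shift toward a higher number is expected to be a 2.9-fold higher number from compound 2 to compound 3 (0.46 log units; beyond the scatter). Compound 3 is accordingly estimated at 1800 nM in this assay, with a range from 500 nM to 6000 nM; a limit rather than a number is unlikely.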

Compound 3, half-maximal inhibitory concentration: 1580 nM
For compound 3 the middle estimate is 1.1-fold (0.06 log units) above the measured one, within the range that was stated.
By their numbers in this assay, from the lowest: compound 2; then compounds 1 and 3 (each within the scatter of the next).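

In this assay, among the compounds shown here, the change of acetamido to acetamidomethyl on a saturated chain carbon, three bonds along the chain from an oxygen on an aromatic ring, gives a 2.5-fold higher number from compound 2 to compound 3 (0.40 log units; beyond the scatter) and is the first single-place step. It shows that this position is sensitive to chain length: read as acetamidomethyl to 2-acetamidoethyl, a single added saturated carbon moves the number beyond the scatter, and the move is upward, with the shorter chain of compound 2 holding the lower number of this pair. The measurements at hand offer nothing that bears on why the added carbon has this effect.

From the compounds shown here alone, one step gives a direction but not a curve, so it remains open whether a still longer chain raises the number further or whether a shorter chain lowers it. Going by these compounds, it is also open whether the same length dependence holds when the acetamide is replaced by a propionamide or an amine, or whether it holds only for the acetamide end of the chain.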